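Tail substituent swap on a shared core: notes

The compounds below may be only part of what the source reports. "The series", "measured", "known", "first", "only" and "open" are said of these compounds alone.

Measured so far in a functional assay on MCF7 cells (Homo sapiens) for inhibition, read by sulforhodamine B assay; on this read-out higher numbers stand for weaker inhibition of growth and lower numbers for stronger inhibition of growth:
compound 1, `FC(F)(F)c1ccc(-c2ccc(-c3ccc(-c4nc5ccccc5[nH]4)cc3)cc2)cc1`, gives 41400 nM.
compound 2, `FC(F)(F)Oc1ccc(-c2ccc(-c3ccc(-c4nc5ccccc5[nH]4)cc3)cc2)cc1`, gives 38400 nM.
compound 3, `Cc1ccc2[nH]c(-c3ccc(-c4ccc(-c5ccc(C(F)(F)F)cc5)cc4)cc3)nc2c1`, gives 31000 nM.

Compounds 1 and 2 share one core; compounds 3 and 4 share another, and the two cores differ by methyl in place of hydrogen on an aromatic carbon. That core change gave a 1.3-fold lower number from compound 1 to compound 3 (0.13 log units; within the scatter).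

The change from compound 1 to compound 2 is trifluoromethoxy in place of trifluoromethyl on an aromatic carbon, and it gave a 1.1-fold lower number from compound 1 to compound 2 (0.03 log units; within the scatter). The unmeasured compound 4, `Cc1ccc2[nH]c(-c3ccc(-c4ccc(-c5ccc(OC(F)(F)F)cc5)cc4)cc3)nc2c1`, differs from compound 3 by trifluoromethoxy in place of trifluoromethyl on an aromatic carbon. The two place descriptions read the same, so the change is taken as the same change on the other core, and it occurs twice among these four compounds.

For compound 4 the expected step is a 1.1-fold lower number from compound 3 to compound 4 (0.04 log units; within the scatter), because the earlier 1.1-fold lower number from compound 1 to compound 2 (0.03 log units; within the scatter) stayed within the scatter and nothing here suggests the second core would respond differently. All three measured numbers sit close together, so no ordering among them is claimed. The estimate for compound 4 in this assay is 28000 nM, with a range expected from 14000 nM to 56000 nM.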

Compound 4, concentration for 50% growth inhibition: 31000 nM
The estimate for compound 4 lay 1.1-fold (0.04 log units) below the measured number; the measured number falls inside the stated range.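

In this assay, trifluoromethoxy in place of trifluoromethyl gave no change at the digits printed from compound 3 to compound 4 (within the scatter), and this step matches the one on the other core: the same change on two cores in this assay, a 1.1-fold lower number (0.03 log units; within the scatter) from compound 1 to compound 2 and no change at the digits printed (within the scatter) from compound 3 to compound 4, 1.1-fold (0.03 log units) apart, within the scatter of two such steps. Methyl in place of hydrogen on an aromatic carbon gave a 1.2-fold lower number from compound 2 to compound 4 (0.09 log units; within the scatter), and this step matches the one seen with the trifluoromethyl tail: the same change on two cores in this assay, a 1.3-fold lower number (0.13 log units; within the scatter) from compound 1 to compound 3 and a 1.2-fold lower number (0.09 log units; within the scatter) from compound 2 to compound 4, 1.1-fold (0.03 log units) apart, within the scatter of two such steps. Across these four compounds, both changes therefore read the same on either side of the swap, but every step lies within the scatter, so the agreement shows only that neither change moved the number measurably here, not that a step of real size would carry from one core to another.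

Going by these compounds, it remains open whether an amine, a carboxylic acid or a longer chain in place of trifluoromethyl would give a step beyond the scatter, and whether such a step would hold on both cores. Also open, on these data alone, is whether either change would behave the same way on any core other than these two.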